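A methyl added to the propoxy chain of compound 3

The compounds below may be only part of what the source reports. "The series", "measured", "known", "first", "only" and "open" are said of these compounds alone.

Values measured so far in a functional assay on the whole organism with Scenedesmus acutus as the target; a lower number here means a stronger inhibitor, a higher number a weaker inhibitor:
compound 1 `COC(=O)c1cc(N2C(=O)C3=C(CCCC3)C2=O)ccc1Cl`: 2000 nM
compound 2 `CCCOC(=O)c1cc(N2C(=O)C3=C(CCCC3)C2=O)c(F)cc1Cl`: 89.1 nM
compound 3 `CCCOC(=O)c1cc(N2C(=O)C3=C(CCCC3)C2=O)ccc1Cl`: 1860 nM

Compound 3 stands level with compound 1 within the scatter, and its number is far higher than that of compound 2. Compound 4 `CCC(C)OC(=O)c1cc(N2C(=O)C3=C(CCCC3)C2=O)ccc1Cl` differs from compound 3 only in its chain, where propoxy becomes sec-butoxy. The change in full: methyl in place of hydrogen on a saturated chain carbon bound to an oxygen next to a carbonyl group and a saturated chain carbon.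

Going by the values given here, only one measured step touches this chain, a 1.1-fold lower number from compound 1 to compound 3 (0.03 log units; within the scatter), and it stayed within the scatter. The other measured step, a 21-fold higher number from compound 2 to compound 3 (1.32 log units; beyond the scatter), is large, but it concerns fluoro on an aromatic carbon and not the chain, so it offers little guidance here. No branched chain has been measured, so the evidence is thin. Even so, no step beyond the scatter is expected in this assay. The expected step is a 1.0-fold lower number from compound 3 to compound 4 (0.01 log units; within the scatter). For compound 4 the estimated value is 1800 nM, with an expected range from 700 nM to 4500 nM.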

Compound 4, half-maximal inhibitory concentration: 794 nM
For compound 4 the middle estimate is 2.3-fold (0.36 log units) above the measured one, within the range that was stated.
By their numbers in this assay, from the lowest: compound 2; then compound 4; then compounds 3 and 1 (each within the scatter of the next).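

This chain position is not indifferent in this assay: replacing hydrogen with ethyl on the chain carbon left the number level, with a 1.1-fold lower number from compound 1 to compound 3 (0.03 log units; within the scatter), whereas the single added methyl that turns propoxy into sec-butoxy gives a 2.3-fold lower number from compound 3 to compound 4 (0.37 log units; beyond the scatter). The same branched chain also separates from the shortest chain shown, with a 2.5-fold lower number from compound 1 to compound 4 (0.40 log units; beyond the scatter), so among these three compounds only the sec-butyl compound stands apart, though by a modest step. Nothing available explains this shift.

As far as these compounds go, whether the fluoro on the aromatic carbon that separates compound 2 from compound 3 would combine with the sec-butoxy chain remains open. Also open, from the compounds shown here alone, is how this assay would respond to a tert-butyl group or a longer chain such as pentyl.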